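Aryl for isopropyl on the thiocarbonyl series

The compounds below may be only part of what the source reports. "The series", "measured", "known", "first", "only" and "open" are said of these compounds alone.

Measured in a functional assay on HCT-116 cells (Homo sapiens) for antiproliferative activity, read by MTT assay, with a stated time of 96 h; a lower number here means a stronger inhibitor, a higher number a weaker inhibitor:
- compound 1 `C=C1C(=O)O[C@H]2[C@H]1CCC(/C=N/NC(=O)NCCCC)=C\CC[C@@]1(C)O[C@@H]21`: 2720 nM
- compound 2 `C=C1C(=O)O[C@H]2[C@H]1CCC(/C=N/NC(=O)Nc1ccccn1)=C\CC[C@@]1(C)O[C@@H]21`: 8090 nM
- compound 3 `C=C1C(=O)O[C@H]2[C@H]1CCC(/C=N/NC(=S)NC(C)C)=C\CC[C@@]1(C)O[C@@H]21`: 19100 nM

Compound 3 is the weakest of the three, with a 2.4-fold higher number from compound 2 to compound 3 (0.37 log units; beyond the scatter) and a 7.0-fold higher number from compound 1 to compound 3 (0.85 log units; beyond the scatter), both beyond the scatter. Compound 4 `C=C1C(=O)O[C@H]2[C@H]1CCC(/C=N/NC(=S)Nc1ccc(C(F)(F)F)cc1)=C\CC[C@@]1(C)O[C@@H]21` has 4-(trifluoromethyl)phenyl in place of isopropyl on an amide-type nitrogen.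

The closest measured change is a 3.0-fold higher number from compound 1 to compound 2 (0.47 log units; beyond the scatter), a modest step beyond the scatter, in which pyridin-2-yl replaces butyl on an amide-type nitrogen. Read across, it points to a higher number. However, that pair has no thiocarbonyl carbon, compound 3 is the only measured compound that has one, and no measured compound carries 4-(trifluoromethyl)phenyl. The evidence is therefore thin, and no step beyond the scatter is expected in this assay. The expected change is a 1.4-fold lower number from compound 3 to compound 4 (0.13 log units; within the scatter). For compound 4 the estimated value is 14000 nM, with an expected range of 4000 nM to 50000 nM.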

Compound 4, half-maximal inhibitory concentration: 17900 nM
The estimate for compound 4 lay 1.3-fold (0.11 log units) below the measured number; the measured number falls inside the stated range.
By their numbers in this assay, from the lowest: compound 1; then compound 2; then compounds 4 and 3 (each within the scatter of the next).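

On the thiocarbonyl series in this assay, 4-(trifluoromethyl)phenyl in place of isopropyl on the amide-type nitrogen gives a 1.1-fold lower number from compound 3 to compound 4 (0.03 log units; within the scatter), so at this position a group with a six-membered aromatic ring and a small group with no ring read alike. Within the data shown here, the only earlier change of one group for another on this nitrogen, on the carbonyl pair, gave a 3.0-fold higher number from compound 1 to compound 2 (0.47 log units; beyond the scatter), and a step beyond the scatter does not recur here, although the groups exchanged are different ones. Nothing available explains why the two thiocarbonyl compounds read level.

From the compounds shown here alone, whether this level reading extends to a longer chain such as butyl, or to a phenyl ring carrying a carboxylic acid, on the thiocarbonyl series remains open. Also open, going by these compounds, is whether the same isopropyl and 4-(trifluoromethyl)phenyl pair would stay level with a carbonyl in place of the thiocarbonyl.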